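The compounds below may be only part of what the source reports. "The series", "measured", "known", "first", "only" and "open" are said of these compounds alone.

Measured so far in an ADME assay on Caco-2 cells (Homo sapiens) for permeability, with a stated time of 2 h; on this read-out lower numbers stand for lower permeability and higher numbers for higher permeability:
- Compound 1 `COc1cc2c(cc1OC)CN(Cc1coc(-c3ccc4ccccc4c3)n1)CC2`: 0.38 nm/s
- Compound 2 `COc1cc2c(cc1OC)CN(Cc1coc(-c3ccc4cc(F)ccc4c3)n1)CC2`: 0.82 nm/s

In this assay compound 2 stands highest of the two, at 0.82 nm/s. Compound 3 `COc1ccc2cc(-c3nc(CN4CCc5cc(OC)c(OC)cc5C4)co3)ccc2c1` carries methoxy in place of fluoro on an aromatic carbon. Among the measured compounds shown here, only one measured step bears on this, a modest one of fluoro in place of hydrogen: a 2.2-fold higher number from compound 1 to compound 2 (0.33 log units; beyond the scatter). It involves no methoxy, so it gives no firm direction, and no change beyond the scatter is expected. The expected change is a 1.2-fold lower number from compound 2 to compound 3 (0.07 log units; within the scatter). For compound 3 the estimated value is 0.7 nm/s, with an expected range from 0.25 nm/s to 1.9 nm/s.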

Compound 3, apparent permeability: 3.8 nm/s
Estimate against measurement, compound 3: 5.4-fold (0.73 log units) below; measured number above the stated range.
By their numbers in this assay, from the lowest: compound 1; then compound 2; then compound 3.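

At this position on the shared core, the nature of the group matters more than the fluoro step alone could show: in this assay, methoxy in place of fluoro gives a 4.6-fold higher number from compound 2 to compound 3 (0.67 log units; beyond the scatter), and methoxy in place of hydrogen gives a 10-fold higher number from compound 1 to compound 3 (1.00 log units; beyond the scatter). Both groups thus give a higher number than hydrogen, and methoxy gives the highest of the three. Nothing available explains this difference.

The compounds shown leave open whether an ethoxy group, an amine or a carboxylic acid at this position would raise the number further or lower it. They also leave open whether methoxy would give a similar step on another aromatic carbon.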